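The source may report more compounds than this note shows. Statements on the series, on what has been measured and on what is new or still open speak of the compounds shown alone.

Compounds measured:
- Compound 1, `N#Cc1cnc(NCc2cnccc2C(F)(F)F)cc1N[C@H]1C[C@H](O)C1`: 900 nM
- Compound 2, `N#Cc1cnc(NCc2cnccc2C(F)(F)F)cc1N[C@H]1CC[C@H](O)CC1`: 350 nM
- Compound 3, `CO[C@H]1CC[C@@H](CNc2cc(NCc3cnccc3C(F)(F)F)ncc2C#N)CC1`: 70 nM

All three share one core and differ only in the group carried on a nitrogen on an aromatic ring; the values above come from an assay on isolated protein for inhibition of protein kinase C theta type (Homo sapiens), read by TR-FRET, with a stated time of 2 h; on this read-out lower numbers stand for stronger inhibition and higher numbers for weaker inhibition. Compound 3 stands lowest of the three: the nearest neighbour is compound 2, a step of a 5.0-fold lower number from compound 2 to compound 3 (0.70 log units; beyond the scatter), and the furthest is compound 1, a step of a 13-fold lower number from compound 1 to compound 3 (1.11 log units; beyond the scatter).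

Compound 4, `N#Cc1cnc(NCc2cnccc2C(F)(F)F)cc1NCC1CCOCC1`, is not yet measured. It differs from compound 3 in one place: oxan-4-yl in place of 4-methoxycyclohexyl on a saturated chain carbon bound to a nitrogen on an aromatic ring. The methoxy substituent of the cyclohexyl ring is gone and an oxygen now sits in the ring. Within the data shown here, no measured step makes exactly this change. The closest guide is a 5.0-fold lower number from compound 2 to compound 3 (0.70 log units; beyond the scatter), which shows that swapping a hydroxycyclohexyl for a methoxycyclohexylmethyl group gave a modest gain; a 2.6-fold lower number from compound 1 to compound 2 (0.41 log units; beyond the scatter) and a 13-fold lower number from compound 1 to compound 3 (1.11 log units; beyond the scatter) concern ring size and the methylene spacer as well. Compound 4 keeps the spacer but loses the methoxy group, so a modest loss is expected, a 2.9-fold higher number from compound 3 to compound 4 (0.46 log units; beyond the scatter), in this assay. Compound 4 is therefore estimated at 200 nM, within 70 nM to 600 nM.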

Compound 4, half-maximal inhibitory concentration: 400 nM
For compound 4 the middle estimate is 2.0-fold (0.30 log units) below the measured one, and the stated range covers the measured number.
By their numbers in this assay, from the lowest: compound 3; then compounds 2 and 4 (each within the scatter of the next); then compound 1.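

In this assay, replacing 4-methoxycyclohexyl with oxan-4-yl on the same saturated chain carbon gives a 5.7-fold higher number from compound 3 to compound 4 (0.76 log units; beyond the scatter) and so shows that the methylene spacer alone does not hold the level of compound 3. The (oxan-4-yl)methyl group cannot be told apart from 4-hydroxycyclohexyl, with a 1.1-fold higher number from compound 2 to compound 4 (0.06 log units; within the scatter), but it keeps a margin over 3-hydroxycyclobutyl, with a 2.3-fold lower number from compound 1 to compound 4 (0.35 log units; beyond the scatter). No available evidence bears on the size of the loss at this position.

The compounds shown leave open whether the loss follows from removing the methoxy group, from placing oxygen in the ring, or from both. A plain cyclohexylmethyl group and a (4-hydroxycyclohexyl)methyl group on the same nitrogen would separate these changes, and a (4-ethoxycyclohexyl)methyl group would test how far the ether can be extended.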